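This account rests on a few compounds, and the source may have more. Where it says the series, first, only, none or still open, it means among the compounds named here.

Measured so far:
compound 1, `C#CCOc1cccc(/C=C/C(=O)Nc2cc(C(=O)c3cc(OC)c(OC)c(OC)c3)ccc2OC)c1`: 13100 nM
compound 2, `COc1cc(C(=O)c2cc(OC)c(OC)c(OC)c2)cc(NC(=O)/C=C/c2cc(OC)c(OC)c(OC)c2)c1OC`: 4800 nM

Both numbers come from a functional assay on PC-3 cells (Homo sapiens) for cytotoxicity, read by MTT assay, with a stated time of 72 h; on this read-out lower numbers stand for stronger inhibition and higher numbers for weaker inhibition. Going by the values given here, on these two numbers compound 2 stands lowest; its only neighbour, compound 1, sits beyond the scatter above it. The two differ in the aryl group carried on the double-bonded chain carbon, and that is also the part changed in the next compound.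

Compound 3, `COc1cc(C(=O)c2cc(OC)c(OC)c(OC)c2)cc(NC(=O)/C=C/c2ccc(C(F)(F)F)cc2)c1OC`, has not yet been measured in this assay. Relative to compound 2 the change is 4-(trifluoromethyl)phenyl in place of 3,4,5-trimethoxyphenyl on a double-bonded chain carbon bound to a double-bonded chain carbon. Among the compounds with values here, no pair of measured compounds covers this replacement, so the expectation can rest only on what compound 1 and compound 2 show: the one exchange of the aryl group on that chain seen so far goes with a higher number, compound 1 giving 13100 nM where compound 2 gives 4800 nM. The entering 4-(trifluoromethyl)phenyl group appears in neither measured compound, so the expectation carries moderate confidence only. The expected step is a 1.9-fold higher number from compound 2 to compound 3 (0.27 log units; within the scatter), a loss of roughly the size seen between the two measured compounds. For compound 3 the estimate in this assay is 9000 nM, with a range from 2500 nM to 30000 nM.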

Compound 3, half-maximal inhibitory concentration: 4200 nM
Compound 3: the middle estimate sits 2.1-fold (0.33 log units) above what was measured; low and high end bracket the measured number.
By their numbers in this assay, from the lowest: compounds 3 and 2 (each within the scatter of the next); then compound 1.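

In this assay, 4-(trifluoromethyl)phenyl in place of 3,4,5-trimethoxyphenyl on a double-bonded chain carbon bound to a double-bonded chain carbon gives a 1.1-fold lower number from compound 2 to compound 3 (0.06 log units; within the scatter) and so leaves the number where it was. At this position, then, an aryl group with 0 hydrogen-bond acceptors and fluorine in place of oxygen serves as well in this cell read-out as one with 3 hydrogen-bond acceptors, and the trimethoxy pattern is not required to hold this level of cytotoxicity. Nothing measured alongside these numbers bears on why the two groups read alike.

Going by these compounds, both groups are uncharged and each carries one six-membered aromatic ring of carbon only, so it remains open whether an aryl group bearing an amine or a carboxylic acid would hold the same level. On these data alone, it also remains open whether the aromatic ring itself is needed at this position, which a simple longer alkyl chain in its place would test.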